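From 2-methyl-1,3-thiazol-4-yl to pyrimidin-2-yl on the shared core

This account rests on a few compounds, and the source may have more. Where it says the series, first, only, none or still open, it means among the compounds named here.

In an in vivo ADME assay on the whole organism (strain 129/SvEvBrd x C57BL/6) for pharmacokinetics, with Mus musculus as the target, at a dose of 1 mg/kg by the intravenous route (on this read-out higher numbers stand for fast clearance and lower numbers for slow clearance), compound 2 (`Cc1nc(-c2nc([C@@H](O)[C@H](O)[C@H](O)CO)c[nH]2)cs1`) gives 19.4 mL/min/kg and compound 1 (`CCc1[nH]c(C(C)=O)nc1[C@@H](O)[C@H](O)[C@H](O)CO`) gives 17.3 mL/min/kg on the same scale. Among the measured compounds shown here, these two values lie within the scatter of each other, so compound 2 stands level with the only other measured compound and neither can be ranked.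

Compound 3 (`OC[C@@H](O)[C@@H](O)[C@H](O)c1c[nH]c(-c2ncccn2)n1`) carries pyrimidin-2-yl in place of 2-methyl-1,3-thiazol-4-yl on an aromatic carbon of a five-membered aromatic ring with 2 nitrogen, between two ring nitrogen atoms (pyrimidin-2-yl in place of 2-methyl-1,3-thiazol-4-yl on an aromatic carbon). For the measured compounds named here, no measured step covers this change, or any other change, so the data give no direction for it. Going by the values given here, the only anchors are compound 1 at 17.3 mL/min/kg and compound 2 at 19.4 mL/min/kg and the expectation stays close to them.

No step beyond the scatter is expected in this assay and the estimated size is small (a 1.1-fold lower number from compound 2 to compound 3 (0.03 log units; within the scatter)). The estimate for compound 3 is 18 mL/min/kg within an expected range from 9 mL/min/kg to 36 mL/min/kg on this thin evidence.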

Compound 3, clearance: 15.2 mL/min/kg
Compound 3: middle estimate off by 1.2-fold (0.07 log units), on the high side, and the stated range covers the measured number.
By their numbers in this assay, from the lowest: compounds 3, 1 and 2 (each within the scatter of the next).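

Among the compounds shown here, this is the first step that can be read at this position. In this assay, placing pyrimidin-2-yl in place of 2-methyl-1,3-thiazol-4-yl on the aromatic carbon between two ring nitrogen atoms gives a 1.3-fold lower number from compound 2 to compound 3 (0.11 log units; within the scatter), so the clearance of the two compounds cannot be told apart. The exchange replaces a five-membered aromatic ring with a six-membered one and a sulfur with a nitrogen, while the heavy-atom, donor and acceptor counts of the group stay the same, and on this pair neither ring size nor that exchange of hetero atom shows a step beyond the scatter. No measurement on hand accounts for this reading, so the pair gives a result without an explanation.

Going by these compounds, what a carboxylic acid, an amine or an open alkyl chain on this same aromatic carbon would do to clearance remains open, as the two rings compared here are both aromatic groups of equal size. Also open, on these data alone, is whether a shorter chain in place of the group of 8 heavy atoms would give a step beyond the scatter on the shared core.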